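This account rests on a few compounds, and the source may have more. Where it says the series, first, only, none or still open, it means among the compounds named here.

Compound 1 `Cc1cc(NC(=O)Nc2ccc(F)cc2)c2ccccc2n1` — > 25000 nM, a limit of the assay rather than a number.
Compound 2 `Cc1cc(NC(=O)Nc2cccc(F)c2)c2ccccc2n1` — > 25000 nM, likewise a limit of the assay rather than a number.
Compound 3 `COC(=O)c1ccc(NC(=O)Nc2cc(C)nc3ccccc23)cc1` — 17000 nM.

The three compounds share one core and differ only in the aryl group on the urea nitrogen. In an ADME assay on Raji cells (Homo sapiens) for cytotoxicity, with a stated time of 72 h (a lower number here means that less compound is needed, a higher number that more compound is needed for the effect), compound 1 gives > 25000 nM, which is a limit of the assay and not a number. Compound 2 gives > 25000 nM in this assay, again a limit and not a number. The two differ in that (3-fluorophenyl in place of 4-fluorophenyl on an amide-type nitrogen). The step between them is a step that the two limits leave unreadable from compound 1 to compound 2. Compound 3 gives 17000 nM in this assay, and it differs from compound 1 in that (methoxycarbonyl in place of fluoro on an aromatic carbon), giving an at least 1.4-fold lower number from compound 1 to compound 3 (0.16 log units; that floor lies within the scatter). Two of the three values sit at the limit of > 25000 nM in this assay, at which 2 of the 3 values shown sit, so little can be read from this set.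

Compound 4 `COC(=O)c1cccc(NC(=O)Nc2cc(C)nc3ccccc23)c1` has not yet been measured in this assay. It differs from compound 2 in that (methoxycarbonyl in place of fluoro on an aromatic carbon). This is the same kind of change as from compound 1 to compound 3, though not the same, since in compound 4 the new group stands meta to a large group, while in compound 3 it stands para to a large group. Compound 4 is expected to give about 20000 nM in this assay, between 8000 nM and 50000 nM, a step of an at least 1.2-fold lower number from compound 2 to compound 4 (0.09 log units; that floor lies within the scatter), because the earlier step of an at least 1.4-fold lower number from compound 1 to compound 3 (0.16 log units; that floor lies within the scatter) from compound 1 to compound 3 stayed close to the scatter and compound 2 sits at a limit.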

Compound 4, half-maximal effective concentration: 26000 nM
Compound 4: middle estimate off by 1.3-fold (0.11 log units), on the low side, within the range that was stated.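

In this assay no new step can be read from compound 2 to compound 4, because the value of compound 2 is a limit of the assay and not a number: the limit of > 25000 nM in this assay, at which 2 of the 4 values shown sit. The compounds shown leave open whether methoxycarbonyl in place of fluoro on an aromatic carbon changes the number in this assay at all.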